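From compound 3 to compound 4: a longer chain group

The source may hold more compounds than are shown below. What is called first, only, known or untested is meant among the compounds shown, and "the series" means these compounds.

Measured in a functional assay on MDA-MB-231 cells (Homo sapiens) for cytotoxicity, read by MTT assay, with a stated time of 72 h (on this read-out lower numbers stand for stronger inhibition and higher numbers for weaker inhibition), so far
- Compound 1 `O=C1c2c[n+]([O-])c3ccccc3c2C(=O)c2c1c1ccccc1n2CCCCn1ccnc1` gives 210 nM
- Compound 2 `O=C1c2c[n+]([O-])c3ccccc3c2C(=O)c2c1c1ccccc1n2CCN1CCCC1` gives 630 nM
- Compound 3 `O=C1c2c[n+]([O-])c3ccccc3c2C(=O)c2c1c1ccccc1n2CCN1CCCCC1` gives 1050 nM

Compound 3 lies within the scatter of compound 2, and compound 1 has a clearly lower number than both. Compound 4 `CN1CCN(CCCCCCn2c3c(c4ccccc42)C(=O)c2c[n+]([O-])c4ccccc4c2C3=O)CC1` changes a single place in compound 3 (4-(4-methylpiperazin-1-yl)butyl in place of piperidin-1-yl on a saturated chain carbon, two bonds along the chain from an aromatic nitrogen). The swap of pyrrolidin-1-yl for piperidin-1-yl (a 1.7-fold higher number from compound 2 to compound 3 (0.22 log units; within the scatter)) stays within the scatter and offers little guidance. For the measured compounds named here, only one measured step takes a long chain group away at this place (a 5.0-fold higher number from compound 1 to compound 3 (0.70 log units; beyond the scatter)). Read in reverse, it points to a modest fall in the number expected for compound 4 in this assay, although no measured compound carries 4-(4-methylpiperazin-1-yl)butyl. The estimated change is a 2.5-fold lower number from compound 3 to compound 4 (0.40 log units; beyond the scatter) and remains uncertain. For compound 4 the estimate is 420 nM within an expected range (130 nM to 1300 nM).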

Compound 4, half-maximal inhibitory concentration: 2400 nM
Beside the measured number, compound 4's estimate is 5.7-fold (0.76 log units) below it, and the stated range ends below it.
By their numbers in this assay, from the lowest: compound 1; then compounds 2 and 3 (each within the scatter of the next); then compound 4.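

In this assay a longer chain group at this place does not by itself bring the number down: 4-(4-methylpiperazin-1-yl)butyl raises it (a 2.3-fold higher number from compound 3 to compound 4 (0.36 log units; beyond the scatter)) and also stands clearly above the shorter pyrrolidine compound (a 3.8-fold higher number from compound 2 to compound 4 (0.58 log units; beyond the scatter)). The long chain of compound 1 ends in an imidazole and lies far lower (an 11-fold higher number from compound 1 to compound 4 (1.06 log units; beyond the scatter)), so chain length alone does not set the number across these compounds.

Going by these compounds, compound 1 and compound 4 differ in both chain length and end ring, so whether a morpholine ring or an imidazole on the longer chain would lower the number stays open. No supporting data explain these differences.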